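From formyl to 2-acetylethenyl: a cytotoxicity estimate

The source may hold more compounds than are shown below. What is called first, only, known or untested is meant among the compounds shown, and "the series" means these compounds.

Measured in an ADME assay on HEK293 cells (Homo sapiens) for cytotoxicity, with a stated time of 72 h; a higher number here means that more compound is needed for the effect, a lower number that less compound is needed:
- compound 1 `C=C[C@@](C)(/C=C/c1ccc(OS(=O)(=O)c2ccc(C)cc2)cc1)CCC=C(C)C`: > 36600 nM (a limit of the assay, not a number)
- compound 2 `C=C[C@@](C)(/C=C/c1ccc(O)cc1)CC/C=C/C(=O)OCc1ccccc1`: > 36600 nM (a limit of the assay, not a number)
- compound 3 `COc1ccc(/C=C/[C@@](C)(/C=C/c2ccc(O)c(C=O)c2)CCC=C(C)C)cc1`: 2270 nM

Only one of these three results is an actual number. Going by the values given here, compound 3 gives 2270 nM, so it is the single compound here with a measured half-maximal effective concentration. The other two results share one ceiling, (the limit of > 36600 nM in this assay, at which 2 of the 3 values shown sit), and they show only that the assay reached its limit.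

The next compound to be tested is compound 4 `COc1ccc(/C=C/[C@@](C)(/C=C/c2ccc(O)c(/C=C/C(C)=O)c2)CCC=C(C)C)cc1`. It keeps the core of compound 3 but has 2-acetylethenyl in place of formyl on an aromatic carbon, ortho to a hydroxy group (2-acetylethenyl in place of formyl on an aromatic carbon).

Among the compounds with values here, no two measured compounds differ in just one place, so the data do not show how large a single change tends to be in this assay. With no such guide, no shift beyond the scatter is expected in either direction, although the uncertainty is wide. The expected step is a 1.1-fold higher number from compound 3 to compound 4 (0.04 log units; within the scatter). This expectation starts from compound 3 at 2270 nM. Compound 4 is expected at 2500 nM, with an estimated range from 700 nM to 10000 nM.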

Compound 4, half-maximal effective concentration: 14600 nM
For compound 4 the middle estimate is 5.8-fold (0.77 log units) below the measured one, and the stated range ends below it.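

Going by these compounds alone, putting 2-acetylethenyl in place of formyl on an aromatic carbon, ortho to a hydroxy group, gives a 6.4-fold higher number from compound 3 to compound 4 (0.81 log units; beyond the scatter), the first single change that can be read in this assay. This position is therefore not indifferent: with the rest of compound 3 kept, a group of 5 heavy atoms in place of one of 2 goes with more compound being needed for the effect on these cells. Compounds 1 and 2 remain limits of the assay and not numbers, and they add nothing to this step: the limit of > 36600 nM in this assay, at which 2 of the 4 values shown sit.

Going by these compounds, one step cannot separate the parts of this change, since the added carbons and the added double bond enter together, so it remains open which of them goes with the higher number. On these data alone, it is also open how this carbon would respond to an amine, a carboxylic acid or a saturated chain of the same length, and whether the same exchange would give a similar step on another core.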